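This account rests on a few compounds, and the source may have more. Where it says the series, first, only, none or still open, it means among the compounds named here.

Measured so far:
compound 1 `Cc1ccc(OCC(=O)N(Cc2cccs2)c2ccn(C)n2)cc1` — 855 nM
compound 2 `CCN(Cc1cccs1)C(=O)c1cc2cc(C)ccc2n1C` — "not active" (no number reported)
compound 3 `CCN(Cc1cccs1)C(=O)CCc1ccc(C)cc1` — 93 nM

All three were read in an assay on HEK293 cells for agonist activity at transient receptor potential cation channel subfamily M member 8 (Homo sapiens), read by fluorescence and calcium flux, with a stated time of 15 min; on this read-out higher numbers stand for an effect only at larger amounts of compound and lower numbers for an effect already at smaller amounts. Compound 1 holds the higher of the two reported numbers; compound 3 gives the lower one, and the gap between them lies beyond the scatter. Compound 2 returned no number.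

Compound 4 `Cc1ccc(OCC(=O)N(Cc2cccs2)c2cnn(C)c2)cc1` has not yet been measured in this assay. It differs from compound 1 in one place: 1-methyl-1H-pyrazol-4-yl in place of 1-methyl-1H-pyrazol-3-yl on an amide-type nitrogen. Among the compounds with values here, no measured pair shows this change, so no step can be read from the data. The expectation for compound 4 is a small move from compound 1, direction uncertain, more likely toward a higher number. Compound 4 is estimated at 1200 nM in this assay, within 300 nM to 5000 nM. The expected step is a 1.4-fold higher number from compound 1 to compound 4 (0.15 log units; within the scatter).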

Compound 4, half-maximal effective concentration: 63000 nM
Compound 4: the middle estimate sits 53-fold (1.72 log units) below what was measured; measured number above the stated range.
By their numbers in this assay, from the lowest: compound 3; then compound 1; then compound 4.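

In this assay placing 1-methyl-1H-pyrazol-4-yl in place of 1-methyl-1H-pyrazol-3-yl on the amide-type nitrogen gives a 74-fold higher number from compound 1 to compound 4 (1.87 log units; beyond the scatter) with the same atoms, joined differently. Within the data shown here, this position therefore responds strongly to how the ring is joined, not only to which atoms it carries; the earlier compounds offered no pair that differed in one place. Nothing measured here accounts for the size of this step. Still open, going by these compounds, is how an unmethylated 1H-pyrazol-3-yl, a phenyl or a pyridin-3-yl ring would read on the same nitrogen.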